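The source may report more compounds than this note shows. Statements on the series, on what has been measured and on what is new or still open speak of the compounds shown alone.

Within the data shown here, compound 3 `C=CCc1cccc(/C=N/NC(=O)Nc2ccc(Oc3ccnc4cc(OCCCN5CCCCC5)c(OC)cc34)c(F)c2)c1OC` stands second highest of the three numbers so far: in a functional assay on MKN-45 cells (Homo sapiens) for cytotoxicity, read by MTT assay, with a stated time of 72 h (a lower number here means a stronger inhibitor, a higher number a weaker inhibitor), compound 3 gives 670 nM. Its neighbours in the series are compound 1 `COc1cc2c(Oc3ccc(NC(=O)N/N=C/c4ccc(OC(F)(F)F)cc4)cc3F)ccnc2cc1OCCCN1CCCCC1`, which in this assay gives 630 nM, and compound 2 `COc1cc2c(Oc3ccc(NC(=O)N/N=C/c4ccc(N(C)C)cc4)cc3F)ccnc2cc1OCCCN1CCCCC1`, which in this assay gives 870 nM. The steps between these three all fall within the scatter: a 1.1-fold higher number from compound 1 to compound 3 (0.03 log units; within the scatter), a 1.3-fold lower number from compound 2 to compound 3 (0.11 log units; within the scatter) and a 1.4-fold higher number from compound 1 to compound 2 (0.14 log units; within the scatter).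

Compound 4 `COc1cc2c(Oc3ccc(NC(=O)N/N=C/c4ccncc4)cc3F)ccnc2cc1OCCCN1CCCCC1` is the next member; it differs from compound 3 by pyridin-4-yl in place of 3-allyl-2-methoxyphenyl on a carbon with a double bond to nitrogen. The three measured steps all change the group on the same carbon with a double bond to nitrogen and none moved the number beyond the scatter, so they bear directly on this change, though none of them brings in a ring with a hetero atom. The expectation for compound 4 in this assay is therefore a step of a 1.3-fold higher number from compound 3 to compound 4 (0.10 log units; within the scatter), that is, nothing clearly beyond the scatter. Compound 4 is estimated at 850 nM, within a range of 350 nM to 2100 nM.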

Compound 4, half-maximal inhibitory concentration: 980 nM
Estimate against measurement, compound 4: 1.2-fold (0.06 log units) below; low and high end bracket the measured number.
By their numbers in this assay, from the lowest: compounds 1, 3, 2 and 4 (each within the scatter of the next).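

In this assay, pyridin-4-yl, the only ring with a hetero atom on this carbon with a double bond to nitrogen, stays within the scatter of all three substituted phenyl groups: a 1.5-fold higher number from compound 3 to compound 4 (0.17 log units; within the scatter), a 1.1-fold higher number from compound 2 to compound 4 (0.05 log units; within the scatter) and a 1.6-fold higher number from compound 1 to compound 4 (0.19 log units; within the scatter). The change from 3-allyl-2-methoxyphenyl removes both the allyl and the methoxy groups and puts nitrogen into the ring, yet the step remains within the scatter, so no change at this position among the four compounds goes beyond it. The data at hand give no explanation for these values.

From the compounds shown here alone, whether a saturated group such as cyclohexyl, or a phenyl ring carrying a carboxylic acid, would move the number beyond the scatter stays open. Also open, going by these compounds, is whether pyridin-3-yl or pyridin-2-yl would give a number different from that of pyridin-4-yl.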